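The compounds below may be only part of what the source reports. "The series", "measured", "known", "first", "only" and "open" are said of these compounds alone.

Two members of the series share a core and differ at a single aromatic carbon. Compound 1 `Cc1cc(NCCO)nc(SCc2nc3ccccc3[nH]2)n1` carries the (2-hydroxyethyl)amino group there, compound 2 `Cc1cc(N2CCNCC2)nc(SCc2nc3ccccc3[nH]2)n1` the piperazin-1-yl group. In a functional assay on PC-3 cells (Homo sapiens) for cytotoxicity, read by MTT assay, with a stated time of 72 h (a lower number here means a stronger inhibitor, a higher number a weaker inhibitor), compound 1 returns only a limit of the assay, > 100000 nM. In this assay compound 2 likewise returns only a limit, > 100000 nM. The step that the two limits leave unreadable from compound 1 to compound 2 is unreadable because both values sit at the limit of > 100000 nM in this assay, at which 2 of the 2 values shown sit. Compound 3 `Cc1cc(Nc2ccc(Br)cc2)nc(SCc2nc3ccccc3[nH]2)n1` has not yet been measured and differs from compound 2 by (4-bromophenyl)amino in place of piperazin-1-yl on an aromatic carbon. No measured step bears on this change: the single step shown has no readable size, and the two values shown do not separate the earlier groups at this carbon. The likeliest outcome for compound 3 is again a limit. For compound 3 the estimate in this assay is 100000 nM, within 30000 nM to 300000 nM. This estimate would mean a number no higher from compound 2 to compound 3 (the limit leaves the size open), expected to stay within the scatter.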

Compound 3, half-maximal inhibitory concentration: 37100 nM
Compound 3: middle estimate off by 2.7-fold (0.43 log units), on the high side; the measured number falls inside the stated range.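

In this assay, (4-bromophenyl)amino at this aromatic carbon gives the only readable value among the compounds shown, so the position can respond to the group placed there, with an at least 2.6-fold lower number from compound 2 to compound 3 (0.43 log units; beyond the scatter). Replacing 2-hydroxyethyl on the nitrogen with 4-bromophenyl gives a step in the same direction, with an at least 2.6-fold lower number from compound 1 to compound 3 (0.43 log units; beyond the scatter). Both sizes remain open on one side because compound 1 and compound 2 each sit at a limit of the assay: the limit of > 100000 nM in this assay, at which 2 of the 3 values shown sit.

The compounds shown do not separate the contribution of the bromine from that of the aromatic ring, a question that a plain phenylamino group at this carbon would address. Also open, from the compounds shown here alone, is whether the place of the bromine on the ring matters, which a 3-bromophenylamino group would test.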